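Cyclopentyl to cyclohexyl on the amide carbonyl: compound 4

The source may hold more compounds than are shown below. What is called first, only, known or untested is meant among the compounds shown, and "the series" means these compounds.

Measured so far in an assay on isolated protein for inhibition of Nitric oxide synthase, inducible (Homo sapiens), read by scintillation counting, with a stated time of 30 min, tested at 50 uM; on this read-out lower numbers stand for less inhibition and higher numbers for more inhibition at the one concentration tested (going by the name of the read-out):
compound 1 `CC1(C)SC(c2cc(Cl)ccc2N)=NN1C(=O)C1CCCC1` gives 21.3%
compound 2 `CC1(C)SC(c2cc(Cl)ccc2N)=NN1C(=O)C1CCCCC1` gives 7.61%
compound 3 `CC1(C)SC(c2ccccc2N)=NN1C(=O)C1CCCC1` gives 42.2%

Compound 3 stands highest of the three, and its step to each of the other two is beyond the scatter. Within the chloro-bearing pair, the change cyclohexyl in place of cyclopentyl on a carbonyl carbon gave a number 13.7 percentage points lower from compound 1 to compound 2 (beyond the scatter). The cores of compound 1 and compound 3 differ by hydrogen in place of chloro on an aromatic carbon, which gave a number 20.9 percentage points higher from compound 1 to compound 3 (beyond the scatter).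

Compound 4 `CC1(C)SC(c2ccccc2N)=NN1C(=O)C1CCCCC1` is not yet measured. It differs from compound 3 by cyclohexyl in place of cyclopentyl on a carbonyl carbon; the change is the same as from compound 1 to compound 2, at the same place. Within the data shown here, the expectation for compound 4 in this assay is a step of a number 13.7 percentage points lower from compound 3 to compound 4 (beyond the scatter), set beside the earlier a number 13.7 percentage points lower from compound 1 to compound 2 (beyond the scatter), resting on the one measured pair only, since no second example of this change is known here. Compound 4 is therefore estimated at 28.5%, with a range of 14% to 42%.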

Compound 4, a percentage reported as inhibition, at one concentration (the size of the read-out at that concentration, not a potency): 28%
Compound 4: the middle estimate sits 0.5 percentage points above what was measured; measured number inside the range.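

In this assay, cyclohexyl in place of cyclopentyl on a carbonyl carbon carries over from the chloro-bearing core to the core without chloro, giving a number 14.2 percentage points lower from compound 3 to compound 4 (beyond the scatter): the same change on two cores in this assay, a number 13.7 percentage points lower (beyond the scatter) from compound 1 to compound 2 and a number 14.2 percentage points lower (beyond the scatter) from compound 3 to compound 4, 0.5 percentage points apart, within the scatter of two such steps

Hydrogen in place of chloro on an aromatic carbon carries over in the same way with cyclohexyl on the carbonyl carbon, giving a number 20.4 percentage points higher from compound 2 to compound 4 (beyond the scatter): the same change on two cores in this assay, a number 20.9 percentage points higher (beyond the scatter) from compound 1 to compound 3 and a number 20.4 percentage points higher (beyond the scatter) from compound 2 to compound 4, 0.5 percentage points apart, within the scatter of two such steps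

Among these compounds, the two changes therefore combine without interference across these four compounds, and none goes against this, but each is seen on only two cores, with a single pair of groups at each place and at one concentration, so this shows neither transfer to other cores or groups nor anything about potency.

The compounds shown leave open whether the trend on the carbonyl carbon extends to cyclobutyl, phenyl or a longer chain. They also leave open how fluoro or methoxy would compare with chloro and hydrogen on the aromatic carbon.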